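This account rests on a few compounds, and the source may have more. Where it says the series, first, only, none or still open, it means among the compounds named here.

Of the compounds shown here, three built on a shared core have been measured in a physicochemical assay for lipophilicity, measured as octanol-water partition; on this read-out higher numbers stand for higher lipophilicity and lower numbers for lower lipophilicity. Compound 1 (`O=C(COc1cccc2ccccc12)N/N=C/c1ccc(O)cc1`) gives 3.73, compound 2 (`C/C(=N\NC(=O)COc1cccc2ccccc12)c1ccccc1`) gives 3.65 and compound 3 (`COc1ccc(/C=N/NC(=O)COc2cccc3ccccc23)cc1OC`) gives 3.51. Compound 2 stands within the scatter of both of the others, so these numbers do not separate the three compounds.

Compound 4 (`C/C(=N\NC(=O)COc1cccc2ccccc12)c1ccc(O)cc1`) has not yet been measured. It departs from compound 2 by a single change: hydroxy in place of hydrogen on an aromatic carbon. This is hydroxy in place of hydrogen on an aromatic carbon, para to a large group, so that phenyl becomes 4-hydroxyphenyl. Among the measured compounds shown here, no measured pair in this small set shows that change on its own, and the evidence for its size in this assay is only indirect. Compound 1 also carries a 4-hydroxyphenyl group, and its 3.73 lies within the scatter of compound 2 at 3.65. That gives little ground for expecting a large step, though the three numbers cannot settle its direction. A small downward move that stays within the scatter is expected, and the estimated change is a number 0.10 log units lower from compound 2 to compound 4 (within the scatter). For compound 4 the expected value is 3.55, with an estimated range from 3.2 to 3.9.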

Compound 4, partition coefficient: 4.44
Compound 4: middle estimate off by 0.89 log units, on the low side; measured number outside the range, above it.
By their numbers in this assay, from the lowest: compounds 3, 2 and 1 (each within the scatter of the next); then compound 4.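

In this assay, among the compounds shown here, hydroxy in place of hydrogen on an aromatic carbon, para to a large group, gives a number 0.79 log units higher from compound 2 to compound 4 (beyond the scatter) as phenyl becomes 4-hydroxyphenyl, and this is the first step in the set to lie beyond the scatter. The presence of 4-hydroxyphenyl does not by itself fix the number at this level: compound 1, which also carries that group, gives 3.73 in this read-out, whereas compound 4 gives 4.44 on the same scale, so the earlier value gave no sign of what this single change would do on compound 2. No measurement at hand accounts for the direction or the size of this step.

The compounds shown leave open whether the step belongs to hydroxy in particular or would also appear with an amine or a carboxylic acid on the same aromatic carbon. For the compounds shown here, they also leave open whether hydroxy in place of hydrogen would give a step of similar size on another member of the series, as this single pair is the only one that shows the change on its own.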